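The source may report more compounds than this note shows. Statements on the series, on what has been measured and on what is new or still open speak of the compounds shown alone.

Working notes on the series. Going by the values given here, in a functional assay on HT-29 cells (Homo sapiens) for inhibition, read by MTT assay, with a stated time of 48 h (on this read-out lower numbers stand for stronger inhibition and higher numbers for weaker inhibition), compound 1 `COc1cc(-c2nnc(SCC(=O)c3ccc(F)cc3)n2-c2ccc(N(C)C)cc2)cc(OC)c1OC` gives 78100 nM, while compound 2 `CCOC(=O)CSc1nnc(-c2cc(OC)c(OC)c(OC)c2)n1-c1ccc(N(C)C)cc1` gives 28800 nM, the lower of the two numbers so far. Among the compounds with values here, the only measured step is a 2.7-fold lower number from compound 1 to compound 2 (0.43 log units; beyond the scatter), a modest one, with ethoxy in place of 4-fluorophenyl on a carbonyl carbon. Next comes compound 3 `COc1cc(-c2nnc(SCC(=O)Nc3ccc(Cl)cc3)n2-c2ccc(N(C)C)cc2)cc(OC)c1OC`, with (4-chlorophenyl)amino in place of ethoxy on a carbonyl carbon. Within the data shown here, no measured compound carries an amino group there, so the measured step transfers only loosely. Compound 1, at 78100 nM, pairs an aromatic ring-bearing group at that place with the higher number, so in this assay a small upward shift is expected, probably not beyond the scatter. The estimated step is a 1.2-fold higher number from compound 2 to compound 3 (0.08 log units; within the scatter). For compound 3 the expected value is 35000 nM, with an estimated range of 9000 nM to 100000 nM.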

Compound 3, half-maximal inhibitory concentration: > 60000 nM
Compound 3: only a limit was reported; the forecaster's own chance of this, stated with the estimate: 10%; middle value at least 1.7-fold (0.23 log units) from the limit.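

Compound 3 is reported only as a limit, > 60000 nM, in this assay. Even so, on a carbonyl carbon whose other neighbour is a saturated chain carbon, (4-chlorophenyl)amino in place of ethoxy gives an at least 2.0-fold higher number from compound 2 to compound 3 (0.31 log units; beyond the scatter), so both groups at this place that carry an aromatic ring now go with a higher number than ethoxy, and no compound shown goes against this. The step between compound 1 and compound 3 cannot be read because the value of compound 3 is a limit: the limit of > 60000 nM in this assay, at which 1 of the 3 values shown sits.

As far as these compounds go, whether the higher numbers follow the aromatic ring, the amide hydrogen or the halogen stays open, as does the order of compound 1 and compound 3. A carboxylic acid, a methylamino group or an unsubstituted anilide at this carbonyl carbon would begin to separate these readings.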